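Trifluoromethyl Gives Way to Fluoro on the Shared Core

This account rests on a few compounds, and the source may have more. Where it says the series, first, only, none or still open, it means among the compounds named here.

Among the measured compounds shown here, compound 2 `FC(F)(F)c1ccccc1NC(=S)N/N=C/c1ccc2ccccc2n1` gives 18800 nM in a functional assay on HeLa cells (Homo sapiens) for antiproliferative activity, read by sulforhodamine B assay, with a stated time of 72 h (a lower number here means a stronger inhibitor, a higher number a weaker inhibitor), the only number recorded there. Compound 1 `COc1ccccc1NC(=S)N/N=C/c1ccc2ccccc2n1` stops at a limit of this assay, > 100000 nM. For the measured compounds named here, the step of an at least 5.3-fold lower number from compound 1 to compound 2 (0.72 log units; beyond the scatter) is the sole measured change, and it starts from the limit (the limit of > 100000 nM in this assay, at which 1 of the 2 values shown sits). Compound 3 `Fc1ccccc1NC(=S)N/N=C/c1ccc2ccccc2n1` differs from compound 2 by fluoro in place of trifluoromethyl on an aromatic carbon. That measured step moved onto trifluoromethyl; the present one moves off it, so a shift toward weaker inhibition is expected, a 2.4-fold higher number from compound 2 to compound 3 (0.38 log units; beyond the scatter). Compound 3 is estimated at 45000 nM, with a range from 15000 nM to 130000 nM.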

Compound 3, half-maximal inhibitory concentration: > 100000 nM
Compound 3: only a limit was reported (the forecaster's own chance of this, stated with the estimate: 35%); at least 2.2-fold (0.34 log units) between middle value and limit.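

On an aromatic carbon ortho to a large group, fluoro in place of trifluoromethyl gives an at least 5.3-fold higher number from compound 2 to compound 3 (0.72 log units; beyond the scatter) in this assay, so a smaller group does not keep the measurable activity, and the size of this step is open-ended. Trifluoromethyl thus remains the only one of the three groups here with a number, while the step between the two limits cannot be read. Most readings at this position are limits rather than numbers: the limit of > 100000 nM in this assay, at which 2 of the 3 values shown sit.

The compounds shown leave open whether chloro, an amine or a longer chain at this position would give a number in this assay.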